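The compounds below may be only part of what the source reports. "The series", "measured", "known", "first", "only" and "open" are said of these compounds alone.

Working notes on the series. Compound 1 `CCN(CC)CCCNc1nc(-c2ccc(NC(=O)Nc3ccccc3)cc2)nc2ccsc12` gives, in a functional assay on NCI-H460 cells (Homo sapiens) for cytotoxicity, read by MTT assay, with a stated time of 72 h (on this read-out higher numbers stand for weaker inhibition and lower numbers for stronger inhibition), a value of 680 nM. Compound 2 `CCN(CC)CCCNc1nc(-c2ccc(NC(=O)Nc3ccccc3F)cc2)nc2ccsc12`, which carries fluoro in place of hydrogen on an aromatic carbon, gives in this assay a value of 370 nM. Going by the values given here, the only step measured so far is a 1.8-fold lower number from compound 1 to compound 2 (0.26 log units; within the scatter), and on the two numbers at hand compound 2 holds the lower one, with compound 1 as its only neighbour within the scatter.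

Compound 3 `CCN(CC)CCCNc1nc(-c2ccc(NC(=O)Nc3ccc(Cl)cc3)cc2)nc2ccsc12` is not yet measured. It differs from compound 2 by 4-chlorophenyl in place of 2-fluorophenyl on an amide-type nitrogen. Among the compounds with values here, no measured step exchanges one halogenated phenyl for another on this nitrogen; the step from compound 1 to compound 2 touches the same ring but only adds a single fluoro, and it stayed within the scatter. The change from compound 2 to compound 3 is therefore expected to give no step beyond the scatter, a 1.1-fold higher number from compound 2 to compound 3 (0.03 log units; within the scatter). For compound 3 the estimate in this assay is 400 nM, with a range from 150 nM to 1100 nM.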

Compound 3, half-maximal inhibitory concentration: 81 nM
Estimate against measurement, compound 3: 4.9-fold (0.69 log units) above; measured number below the stated range.
By their numbers in this assay, from the lowest: compound 3; then compounds 2 and 1 (each within the scatter of the next).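

In this assay, going by these compounds alone, the aryl group on this amide-type nitrogen proves able to move the number beyond the scatter: 4-chlorophenyl in place of 2-fluorophenyl gives a 4.6-fold lower number from compound 2 to compound 3 (0.66 log units; beyond the scatter), whereas the one earlier step on this ring stayed within the scatter. Measured against the unsubstituted phenyl, chloro in place of hydrogen gives an 8.4-fold lower number from compound 1 to compound 3 (0.92 log units; beyond the scatter), so a single substituent on this ring can produce a step beyond the scatter. Nothing at hand accounts for this difference.

Compounds 2 and 3 differ in both the halogen and its place on the ring, so the compounds shown do not separate these two changes; 4-fluorophenyl and 2-chlorophenyl would address that. Also open, from the compounds shown here alone, is whether the lower number extends to 4-bromophenyl or 4-methoxyphenyl.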